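The source may report more compounds than this note shows. Statements on the series, on what has been measured and on what is new or still open speak of the compounds shown alone.

Compound 1 `Cn1c(=O)c(S(=O)(=O)Cc2ccc(F)cc2)cc2cnc(Nc3ccc4[nH]ccc4c3)nc21` and compound 2 `Cn1c(=O)c(S(=O)(=O)c2ccc(F)cc2F)cc2cnc(Nc3ccc4c(c3)C(=O)C(=O)N4)nc21` share one core and differ at the sulfonyl substituent and the anilino group. In a functional assay on K562 cells (Homo sapiens) for inhibition, read by trypan blue exclusion, with a stated time of 72 h (on this read-out higher numbers stand for weaker inhibition and lower numbers for stronger inhibition), compound 1 gives 30000 nM and compound 2 gives 30000 nM; the two values sit level, within the scatter, so compound 1 stands apart from nothing in this set. Compound 3 `Cn1c(=O)c(S(=O)(=O)c2ccc(F)cc2N)cc2cnc(Nc3ccc4[nH]ccc4c3)nc21` carries 2-amino-4-fluorophenyl in place of 4-fluorobenzyl on a sulfonyl sulfur. Going by the values given here, no measured step in this assay covers this change, and the single measured pair offers no guide to its direction; a step of no more than modest size, if any beyond the scatter, is expected: a 1.5-fold lower number from compound 1 to compound 3 (0.18 log units; within the scatter). Compound 3 is therefore estimated at 20000 nM in this assay, with a range from 5000 nM to 40000 nM.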

Compound 3, half-maximal inhibitory concentration: 2000 nM
Compound 3: middle estimate off by 10-fold (1.00 log units), on the high side, outside the stated range (below it).
By their numbers in this assay, from the lowest: compound 3; then compounds 1 and 2 (each within the scatter of the next).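

The group on the sulfonyl sulfur can move this read-out: in this assay, 2-amino-4-fluorophenyl in place of 4-fluorobenzyl gives a 15-fold lower number from compound 1 to compound 3 (1.18 log units; beyond the scatter). The earlier compounds shown here differ in two places, so they gave no reading of this position alone. Nothing at hand accounts for the step.

As far as these compounds go, the change swaps benzyl for phenyl and adds the amino group in one move, so the share of each stays open. A plain 4-fluorophenyl, or a hydroxyl in place of the amino group, would separate them.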